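This account rests on a few compounds, and the source may have more. Where it says the series, first, only, none or still open, it means among the compounds named here.

Compound 3 (`Nc1ccc(C(=O)/C=C/c2ccc3c(c2)B(O)OC3)cc1`) stands in an ADME assay on L929 cells (Mus musculus) for cytotoxicity, read by resazurin assay, with a stated time of 72 h (a lower number here means a stronger inhibitor, a higher number a weaker inhibitor), at > 10 ug/mL as a limit and not a number. Compound 1 (`O=C(/C=C/c1ccc2c(c1)B(O)OC2)c1ccccc1`) gives > 10 ug/mL as a limit as well. Compound 2 (`O=C(/C=C/c1ccc2c(c1)B(O)OC2)c1ccc(O)cc1`) gives > 10 ug/mL as a limit as well. The three compounds thus share the limit of > 10 ug/mL in this assay, at which 3 of the 3 values shown sit, and none of them has a number yet.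

In compound 4 (`O=C(/C=C/c1ccc2c(c1)B(O)OC2)c1cccc(O)c1`), 3-hydroxyphenyl takes the place of 4-aminophenyl on a carbonyl carbon (3-hydroxyphenyl in place of 4-aminophenyl on a carbonyl carbon). For the measured compounds named here, three measured steps bear on this change: a step that the two limits leave unreadable from compound 1 to compound 2 and a step that the two limits leave unreadable from compound 1 to compound 3 and also a step that the two limits leave unreadable from compound 2 to compound 3 as the one that exchanges amino and hydroxy. None of them offers a size to carry over, so no step beyond the scatter is expected in this assay and no direction can be given. What is expected is a step that the limit leaves unreadable from compound 3 to compound 4 as an estimate only. For compound 4 the estimate is 15 ug/mL with an expected range from 6 ug/mL to 40 ug/mL in this assay.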

Compound 4, half-maximal inhibitory concentration: 7.56 ug/mL
The estimate for compound 4 lay 2.0-fold (0.30 log units) above the measured number; the range from low to high includes it.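

For the compounds shown here, with 3-hydroxyphenyl on the carbonyl carbon, compound 4 gives the first number in this assay rather than a limit, so the earlier compounds can now be set against a fixed value. Moving the hydroxy group, as 3-hydroxyphenyl in place of 4-hydroxyphenyl, gives an at least 1.3-fold lower number from compound 2 to compound 4 (0.12 log units; that floor lies within the scatter), while the exchange for 4-aminophenyl gives an at least 1.3-fold lower number from compound 3 to compound 4 (0.12 log units; that floor lies within the scatter), and adding hydroxy to the unsubstituted phenyl gives an at least 1.3-fold lower number from compound 1 to compound 4 (0.12 log units; that floor lies within the scatter). All three are floors only, so they do not separate compound 4 from the other compounds, whose true sizes stay unread: the limit of > 10 ug/mL in this assay, at which 3 of the 4 values shown sit.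

The compounds shown leave open how far compounds 1, 2 and 3 actually lie from compound 4. They also leave open whether a methoxy group or a carboxylic acid in place of the hydroxy group of compound 4 would give a number in this assay.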